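From 2,4-Dichlorophenyl to 4-Methylphenyl, Twice

The compounds below may be only part of what the source reports. "The series", "measured", "known", "first", "only" and "open" are said of these compounds alone.

Compound 1 `CN(C)CCCNc1nc(-c2ccc(NC(=O)Nc3ccc(Cl)cc3Cl)cc2)nc2c(Cl)c(Cl)sc12`: 980 nM
Compound 2 `Cc1ccc(NC(=O)Nc2ccc(-c3nc(NCCCN(C)C)c4sc(Cl)c(Cl)c4n3)cc2)cc1`: 1110 nM
Compound 3 `CN(C)CCNc1nc(-c2ccc(NC(=O)Nc3ccc(Cl)cc3Cl)cc2)nc2ccsc12`: 1650 nM

Three compounds were tested in a functional assay on NCI-H460 cells (Homo sapiens) for cytotoxicity, read by MTT assay, with a stated time of 72 h; on this read-out higher numbers stand for weaker inhibition and lower numbers for stronger inhibition. Compound 1 gives 980 nM in this assay, compound 2 gives 1110 nM, and compound 3 gives 1650 nM. Compound 2 differs from compound 1 only by 4-methylphenyl in place of 2,4-dichlorophenyl on an amide-type nitrogen, and that change gave a 1.1-fold higher number from compound 1 to compound 2 (0.05 log units; within the scatter). Compound 3 carries the same 2,4-dichlorophenyl on its amide-type nitrogen but sits on a different core; the difference between the two cores is not broken down here, and its values stand within the scatter of both compound 1 and compound 2.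

Compound 4 `Cc1ccc(NC(=O)Nc2ccc(-c3nc(NCCN(C)C)c4sccc4n3)cc2)cc1` has not been measured. It differs from compound 3 by 4-methylphenyl in place of 2,4-dichlorophenyl on an amide-type nitrogen, the same change that separates compound 2 from compound 1, made at a place described in the same words. Because compound 1 to compound 2 gave only a 1.1-fold higher number from compound 1 to compound 2 (0.05 log units; within the scatter), compound 4 is expected to stay close to compound 3, with an estimated step of a 1.1-fold higher number from compound 3 to compound 4 (0.05 log units; within the scatter). Compound 4 is therefore estimated at 1870 nM in this assay, with a likely range from 900 nM to 3800 nM.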

Compound 4, half-maximal inhibitory concentration: 1880 nM
Beside the measured number, compound 4's estimate is 1.0-fold (0.00 log units) below it; the measured number falls inside the stated range.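

In this assay, putting 4-methylphenyl in place of 2,4-dichlorophenyl on the amide-type nitrogen of compound 3 gave a 1.1-fold higher number from compound 3 to compound 4 (0.06 log units; within the scatter). Set beside the earlier step, the change carried over from one core to the other with no difference that can be told from the scatter: the same change on two cores in this assay, a 1.1-fold higher number (0.05 log units; within the scatter) from compound 1 to compound 2 and a 1.1-fold higher number (0.06 log units; within the scatter) from compound 3 to compound 4, 1.0-fold (0.00 log units) apart, within the scatter of two such steps This shows that the swap left the number within the scatter on both of these cores, but it does not show that the same would hold on any other core, and with both steps so small, it assigns no real effect to the change in either direction.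

The compounds shown leave open how a pyridyl ring or a 4-carboxyphenyl group would behave on the same amide-type nitrogen, and whether the step would remain this small with such a group. They also leave open whether the agreement between the two steps would survive with a piperidine in place of the dimethylamino group.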